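The source may report more compounds than this note shows. Statements on the series, on what has been measured and on what is new or still open speak of the compounds shown alone.

Compound 1 `Oc1ccc(O)c(COCc2cc(O)cc(Cl)c2O)c1` and compound 2 `Oc1ccc(O)c(COCc2cc(O)ccc2O)c1` were tested in a functional assay on MOLT-4 cells (Homo sapiens) for cytotoxicity, read by MTT assay; on this read-out lower numbers stand for stronger inhibition and higher numbers for weaker inhibition. Compound 1 gives 5800 nM, and compound 2 gives 5600 nM. The two differ in one place only, (hydrogen in place of chloro on an aromatic carbon), and this change gave a 1.0-fold lower number from compound 1 to compound 2 (0.02 log units; within the scatter).

Compound 3 `COCc1cc(O)cc(Cl)c1O` carries a smaller core; how the core of compound 3 differs from the core of compound 1 is not broken down here. In this assay compound 3 gives 64700 nM, which stands at the high end of the three numbers, beyond the scatter from both compound 1 and compound 2.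

Compound 4 `COCc1cc(O)ccc1O` has not yet been measured. It differs from compound 3 by hydrogen in place of chloro on an aromatic carbon. Within the data shown here, this is the same kind of change as the one from compound 1 to compound 2: the position is in both cases ortho to a hydroxy group and meta to a hydroxy group, but in compound 1 it is meta to a large group, while in compound 3 it is meta to a methoxymethyl group. Since the earlier change gave a 1.0-fold lower number from compound 1 to compound 2 (0.02 log units; within the scatter), the step from compound 3 to compound 4 is expected to be small as well, a 1.0-fold higher number from compound 3 to compound 4 (0.00 log units; within the scatter), resting on that single precedent alone. Compound 4 is therefore estimated at 65000 nM in this assay, with a likely range from 30000 nM to 140000 nM.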

Compound 4, half-maximal inhibitory concentration: 86200 nM
Compound 4: middle estimate off by 1.3-fold (0.12 log units), on the low side; the measured number falls inside the stated range.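

Hydrogen in place of chloro gives a 1.3-fold higher number from compound 3 to compound 4 (0.12 log units; within the scatter) in this assay, so this step is too small to count as a real change. Set beside the same change on the core of compound 1, the new step tells the same story: the same change on two cores in this assay, a 1.0-fold lower number (0.02 log units; within the scatter) from compound 1 to compound 2 and a 1.3-fold higher number (0.12 log units; within the scatter) from compound 3 to compound 4, 1.4-fold (0.14 log units) apart, within the scatter of two such steps Across these two pairs, then, the change carries from one core to the other with the same outcome, and the chloro group makes no readable difference to the number on either core, but two pairs cannot show that this would hold on a third core, and they say nothing about why the number stays put.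

The compounds shown carry only chloro or hydrogen at this place, so it remains open whether another group there, such as bromo, methyl, methoxy or an amine, would shift the number beyond the scatter. Going by these compounds, it also remains open what would happen with changes elsewhere on these structures, such as a longer chain in place of the methoxymethyl group, or a carboxylic acid in place of a hydroxy group.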